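A few compounds are considered here, and "the series" means these few. Any claim that something is new, unique, unknown or untested is made for them only; others in the source may bear on it.

Measured so far in a functional assay on HT-29 cells (Homo sapiens) for inhibition, read by luminescence and CellTiter-Glo, with a stated time of 24 h; on this read-out lower numbers stand for an effect already at smaller amounts and higher numbers for an effect only at larger amounts of compound:
- compound 1 `CCCCn1nc(C(=O)N[C@H]2COc3ccccc3N(C)C2=S)nc1Cc1ccccc1`: 510 nM
- compound 2 `CC(C)CCn1nc(C(=O)N[C@H]2COc3ccccc3N(C)C2=S)nc1Cc1ccccc1`: 3640 nM

Among the measured compounds shown here, compound 2, at 3640 nM, holds the higher of the two numbers, and compound 1 is its only neighbour. Next is compound 3 `CN1C(=S)[C@@H](NC(=O)c2nc(Cc3ccccc3)n(CCCO)n2)COc2ccccc21`, not yet measured in this assay. The change from compound 2 is hydroxymethyl in place of isopropyl on a saturated chain carbon, two bonds along the chain from an aromatic nitrogen. Cut one bond further out, it reads isopentyl to 3-hydroxypropyl.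

For the measured compounds named here, one measured step bears on this: a 7.1-fold higher number from compound 1 to compound 2 (0.85 log units; beyond the scatter). It also alters the chain, and it shows that this assay can respond to such a change. Going by the values given here, no measured compound carries a hydroxymethyl group, so the data give no direct reading of direction. The central expectation is therefore a slightly lower number with no move beyond the scatter, although a move in either direction about as large as the measured step remains possible. The expected step is a 1.8-fold lower number from compound 2 to compound 3 (0.26 log units; within the scatter). The estimate for compound 3 is 2000 nM, with an expected range of 500 nM to 10000 nM.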

Compound 3, half-maximal effective concentration: 209 nM
Compound 3: the middle estimate sits 9.6-fold (0.98 log units) above what was measured, outside the stated range (below it).
By their numbers in this assay, from the lowest: compound 3; then compound 1; then compound 2.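

In this assay, among the compounds shown here, the earlier compounds showed only that methyl in place of hydrogen on this chain raised the number. Hydroxymethyl in place of isopropyl now gives a 17-fold lower number from compound 2 to compound 3 (1.24 log units; beyond the scatter), so the same chain also responds strongly in the opposite direction, to a change that brings in a hydroxy group. The comparison with compound 1 shows that this is more than a return from the isopentyl chain: hydroxy in place of methyl gives a 2.4-fold lower number from compound 1 to compound 3 (0.39 log units; beyond the scatter), which places compound 3 lowest of the three, with both of its steps beyond the scatter.

Nothing available here explains either shift, and the added hydrogen-bond donor and acceptor cannot be singled out from the change in heavy atoms and branching. Still open, on these data alone, is whether the hydroxy group itself is needed, which a methoxy group or an amine in its place would test, and whether a longer chain carrying hydroxy would keep the lower number.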